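A few compounds are considered here, and "the series" means these few. Any claim that something is new, unique, unknown or untested is made for them only; others in the source may bear on it.

Measured compounds:
compound 1 `Cc1ccc(OCC(=O)N(C)Cc2cccs2)cc1` gives 400 nM in an assay on HEK293 cells for agonist activity at transient receptor potential cation channel subfamily M member 8 (Homo sapiens), read by fluorescence and calcium flux, with a stated time of 15 min; a lower number here means that less compound is needed, a higher number that more compound is needed for the effect;
compound 2 `C=CCN(Cc1cccs1)C(=O)COc1ccc(C)cc1` gives 20 nM in this assay;
compound 3 `Cc1ccc(OCC(=O)N(Cc2cccs2)c2c(C)n[nH]c2C)cc1` gives 0.3 nM in this assay.

Compound 3 stands lowest of the three numbers: the nearest is compound 2, with a 67-fold lower number from compound 2 to compound 3 (1.82 log units; beyond the scatter), and the furthest is compound 1, with a 1300-fold lower number from compound 1 to compound 3 (3.12 log units; beyond the scatter). Compound 4 `Cc1ccc(OCC(=O)N(Cc2cccs2)c2ncccn2)cc1` has not yet been measured. It differs from compound 3 in one place: pyrimidin-2-yl in place of 3,5-dimethyl-1H-pyrazol-4-yl on an amide-type nitrogen. Within the data shown here, two measured steps bear on this position. The change from methyl to the pyrazolyl group gave a 1300-fold lower number from compound 1 to compound 3 (3.12 log units; beyond the scatter), and from allyl to the same group gave a 67-fold lower number from compound 2 to compound 3 (1.82 log units; beyond the scatter); both show that what sits on this nitrogen moves the number strongly. Among the measured compounds shown here, no measured step compares one aromatic ring with another here, so the size of the step from compound 3 to compound 4 is uncertain. Because compound 3 holds 0.3 nM and the ring is exchanged rather than removed, compound 4 is expected to lose some ground yet remain below compound 1 and compound 2, with the expected step of a 17-fold higher number from compound 3 to compound 4 (1.22 log units; beyond the scatter). The estimate for compound 4 is 5 nM, in a range from 0.5 nM to 50 nM.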

Compound 4, half-maximal effective concentration: 3700 nM
Estimate against measurement, compound 4: 740-fold (2.87 log units) below, and the stated range ends below it.
By their numbers in this assay, from the lowest: compound 3; then compound 2; then compound 1; then compound 4.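

The earlier compounds showed only falling numbers as the group on this amide-type nitrogen changed, whereas here an aromatic ring on it proves no guarantee of a low number in this assay: pyrimidin-2-yl in place of 3,5-dimethyl-1H-pyrazol-4-yl gives a 12000-fold higher number from compound 3 to compound 4 (4.09 log units; beyond the scatter) and is the largest step shown at this position. Pyrimidin-2-yl also falls behind both chain groups, with a 190-fold higher number from compound 2 to compound 4 (2.27 log units; beyond the scatter) against allyl and a 9.3-fold higher number from compound 1 to compound 4 (0.97 log units; beyond the scatter) against methyl, so the identity of the ring counts for more here than the presence of one. Nothing measured here accounts for the difference between the two rings.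

The compounds shown leave open whether ring size, the hydrogen-bond donor or the methyl groups of 3,5-dimethyl-1H-pyrazol-4-yl set it apart from pyrimidin-2-yl, as these all change together in this one step. From the compounds shown here alone, whether phenyl or unsubstituted pyrazol-4-yl on this nitrogen would stand nearer compound 3 or compound 4 also remains open.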